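The compounds below may be only part of what the source reports. "The series", "measured", "known", "first", "only" and "open" are said of these compounds alone.

The three measured compounds share one core and differ only in the aryl group on a carbon with a double bond to nitrogen. Compound 1 `CN(C)CCn1cnnc1-c1cc(Oc2ccc(NC(=O)N/N=C/c3c(Cl)cccc3Cl)cc2F)ccn1` gives 350 nM in a functional assay on NCI-H460 cells (Homo sapiens) for cytotoxicity, read by MTT assay, with a stated time of 72 h; on this read-out higher numbers stand for weaker inhibition and lower numbers for stronger inhibition. Compound 2 `CN(C)CCn1cnnc1-c1cc(Oc2ccc(NC(=O)N/N=C/c3c[nH]c4ccccc34)cc2F)ccn1` gives 1630 nM in this assay, and compound 3 `CN(C)CCn1cnnc1-c1cc(Oc2ccc(NC(=O)N/N=C/c3ccccc3O[N+](=O)[O-])cc2F)ccn1` gives 1270 nM. Compound 3 thus stands second highest of the three numbers; its nearest and furthest neighbours are told by a 1.3-fold lower number from compound 2 to compound 3 (0.11 log units; within the scatter) and by a 3.6-fold higher number from compound 1 to compound 3 (0.56 log units; beyond the scatter).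

Compound 4 `CN(C)CCn1cnnc1-c1cc(Oc2ccc(NC(=O)N/N=C/c3ccc(F)cc3F)cc2F)ccn1` differs from compound 3 in one place: 2,4-difluorophenyl in place of 2-(nitrooxy)phenyl on a carbon with a double bond to nitrogen. The step that bears most directly on this change is a 3.6-fold higher number from compound 1 to compound 3 (0.56 log units; beyond the scatter), in which a 2,6-dichlorophenyl gave way to the 2-(nitrooxy)phenyl and the number rose modestly. Compound 4 moves back toward a dihalogenated phenyl, though with 2,4-difluorophenyl rather than 2,6-dichlorophenyl, so the reverse of that step is only partly applicable. The step of a 4.7-fold higher number from compound 1 to compound 2 (0.67 log units; beyond the scatter) likewise shows that leaving the dichlorophenyl raised the number. A modest lowering in this assay is therefore expected, of about a 2.1-fold lower number from compound 3 to compound 4 (0.33 log units; beyond the scatter). Compound 4 is estimated to give 600 nM in this assay, with a likely range from 250 nM to 1500 nM.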

Compound 4, half-maximal inhibitory concentration: 1930 nM
The estimate for compound 4 lay 3.2-fold (0.51 log units) below the measured number; the whole stated range lies below it.
By their numbers in this assay, from the lowest: compound 1; then compounds 3, 2 and 4 (each within the scatter of the next).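

In this assay, 2,4-difluorophenyl in place of 2-(nitrooxy)phenyl gives a 1.5-fold higher number from compound 3 to compound 4 (0.18 log units; within the scatter) and in place of 1H-indol-3-yl gives a 1.2-fold higher number from compound 2 to compound 4 (0.07 log units; within the scatter), so the 2,4-difluorophenyl group cannot be told apart from either of these two groups at this carbon. Two halogens on the phenyl ring do not in themselves bring the number back to that of compound 1: two dihalogenated phenyl groups are separated by a 5.5-fold higher number from compound 1 to compound 4 (0.74 log units; beyond the scatter), leaving the 2,6-dichlorophenyl as the only one of the four groups shown that stands apart from the rest. Nothing shown here accounts for the gap between these two dihalogenated phenyl groups.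

The four compounds leave open whether the lower number of compound 1 goes with chlorine itself or with where the two halogens sit on the ring, a question that a monochlorophenyl or a 2,4-dichlorophenyl group would bear on. They also leave open how a phenyl ring carrying bromine, a methoxy group or an amine would read at this carbon.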